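Replacing naphthalenylmethyl by methylbenzyl on a sulfanyl chain

The source may report more compounds than this note shows. Statements on the series, on what has been measured and on what is new or still open speak of the compounds shown alone.

Of the compounds shown here, three sharing one core have been measured in a functional assay on HeLa cells (Homo sapiens) for cytotoxicity, read by MTT assay, with a stated time of 72 h; on this read-out lower numbers stand for stronger inhibition and higher numbers for weaker inhibition. Compound 3 `Cc1cc(S(=O)(=O)/N=C(\N)n2nccc2-c2ccccc2)c(SCc2cccc3ccccc23)cc1Cl` gives 3000 nM and stands lowest of the three. Compound 1 `Cc1cc(S(=O)(=O)/N=C(\N)n2nccc2-c2ccccc2)c(SCc2ccc(C(F)(F)F)cc2)cc1Cl` gives 17000 nM, and compound 2 `Cc1cc(-c2ccccc2)n(/C(N)=N/S(=O)(=O)c2cc(C)c(Cl)cc2SCc2ccccc2C)n1`, which carries a different core, gives 160000 nM. The only single-point step among these, a 5.7-fold lower number from compound 1 to compound 3 (0.75 log units; beyond the scatter), shows that the naphthalen-1-yl group on the sulfanyl chain sits clearly lower than a substituted phenyl there.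

Compound 4 `Cc1cc(S(=O)(=O)/N=C(\N)n2nccc2-c2ccccc2)c(SCc2ccccc2C)cc1Cl` is not yet measured. It differs from compound 3 in one place: 2-methylphenyl in place of naphthalen-1-yl on a saturated chain carbon bound to a sulfur. This runs the naphthalenyl step backwards in spirit, shrinking the ring system from two fused rings to one. The step from compound 1 to compound 3 therefore bears on it and suggests a rise of similar size, though the group entering here is a 2-methylphenyl rather than a 4-(trifluoromethyl)phenyl, so the size is uncertain. Compound 2 carries the same 2-methylbenzylsulfanyl group and sits high, but its core is different, so its value can only hint, not measure. For compound 4 the estimate in this assay is 20000 nM, within 6000 nM to 70000 nM, an expected step of a 6.7-fold higher number from compound 3 to compound 4 (0.82 log units; beyond the scatter).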

Compound 4, half-maximal inhibitory concentration: 17000 nM
Compound 4: the middle estimate sits 1.2-fold (0.07 log units) above what was measured; measured number inside the range.
By their numbers in this assay, from the lowest: compound 3; then compounds 1 and 4 (each within the scatter of the next); then compound 2.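

In this assay, the step to 2-methylphenyl on a saturated chain carbon bound to a sulfur gives a 5.7-fold higher number from compound 3 to compound 4 (0.75 log units; beyond the scatter), so naphthalen-1-yl now stands lower than two different single-ring groups rather than one. Exchanging 4-(trifluoromethyl)phenyl for 2-methylphenyl at this place gives no change at the digits printed from compound 1 to compound 4 (within the scatter), so these two single-ring groups cannot be told apart here, even though their substituents differ in kind and in where they sit on the ring. A further comparison opens up on the other side of the molecule, where hydrogen in place of methyl on an aromatic carbon gives a 9.4-fold lower number from compound 2 to compound 4 (0.97 log units; beyond the scatter), a step as large as the naphthalen-1-yl step or larger, with the same 2-methylbenzyl group kept on the sulfur.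

Nothing measured here gives a reason for any of these steps. The compounds shown leave open whether naphthalen-2-yl would match naphthalen-1-yl, and whether a longer chain between the sulfur and the ring, or an amine on that ring, would move the number at all.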